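The compounds below may be only part of what the source reports. "The series", "measured", "known", "first", "only" and "open" are said of these compounds alone.

Of the compounds shown here, two have so far been measured in a functional assay on SF-539 cells (Homo sapiens) for inhibition, read by sulforhodamine B assay, with a stated time of 48 h, tested at 10 uM; a lower number here means a stronger effect, a higher number a weaker effect of the compound at the concentration tested. Compound 1 `COc1cc(Cl)cc(-c2nn(-c3cccc(NC(=O)c4ccc(Cl)c(Cl)c4)c3)cc2-c2ccncc2)c1` gives 74.5% and stands highest of the two numbers; its nearest neighbour, compound 2 `O=C(Nc1cccc(-n2cc(-c3ccncc3)c(-c3cc(O)cc(Cl)c3)n2)c1)Nc1ccc(Cl)c(Cl)c1`, gives -29%, a gap beyond the scatter. Compound 3 `COc1cc(Cl)cc(-c2nn(-c3cccc(NC(=O)Nc4ccc(Cl)c(Cl)c4)c3)cc2-c2ccncc2)c1` awaits measurement. It differs from compound 1 in one place: (3,4-dichlorophenyl)amino in place of 3,4-dichlorophenyl on a carbonyl carbon Compound 2 likewise carries a ((3,4-dichlorophenyl)carbamoyl)amino group, and because compound 2 gives -29% a large downward step is expected in this assay, namely a number 69.5 percentage points lower from compound 1 to compound 3 (beyond the scatter). Compound 3 is accordingly estimated at 5%, within a range from -40% to 55%.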

Compound 3, a percentage reported as activity, at one concentration (the size of the read-out at that concentration, not a potency): 21%
Estimate against measurement, compound 3: 16 percentage points below; the measured number falls inside the stated range.
By their numbers in this assay, from the lowest: compound 2; then compound 3; then compound 1.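

In this assay the change to (3,4-dichlorophenyl)amino on the carbonyl carbon gives a number 53.5 percentage points lower from compound 1 to compound 3 (beyond the scatter) and so shows that this one place alone moves the number strongly. With the ((3,4-dichlorophenyl)carbamoyl)amino group held in both compounds, methyl in place of hydrogen on the oxygen gives a number 50 percentage points higher from compound 2 to compound 3 (beyond the scatter) in the opposite direction, so the oxygen substituent matters as well. Nothing at hand explains either step. As far as these compounds go, how a methylamino or benzylamino group on that carbonyl carbon would read remains open, as does an ethyl group on the oxygen.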